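The source may hold more compounds than are shown below. What is called first, only, known or untested is meant among the compounds shown, and "the series" means these compounds.

In a toxicity assay on THP-1 cells (Homo sapiens) for inhibition (on this read-out higher numbers stand for lower toxicity in this test and lower numbers for higher toxicity in this test), three compounds have been measured so far:

Compound 1 `Cn1c(-c2ccccc2Cl)cnc1NC(=O)c1ncc[nH]1` gives > 50000 nM as a limit
Compound 2 `Cc1ccc(C(=O)Nc2ncc(-c3ccccc3)n2C)cc1` gives > 50000 nM as a limit
Compound 3 `Cn1c(-c2ccccc2)cnc1NC(=O)C1CCCCC1` gives > 100000 nM as a limit

None of these three readings is an exact number. Compound 3 sits at the limit of > 100000 nM in this assay, at which 1 of the 3 values shown sits, and has no exact value to start from. The other two compounds sit at the limit of > 50000 nM in this assay, at which 2 of the 3 values shown sit, so they offer no exact value either.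

The next compound, compound 4 `Cn1c(-c2ccccc2)cnc1NC(=O)c1ncc[nH]1`, has not yet been measured. It carries 1H-imidazol-2-yl in place of cyclohexyl on a carbonyl carbon, and the change counts as follows: 1H-imidazol-2-yl in place of cyclohexyl on a carbonyl carbon.

Going by the values given here, the one measured step at this place is a step that the two limits leave unreadable from compound 2 to compound 3, and it gives no size to carry over. Compound 1 also carries 1H-imidazol-2-yl on a carbonyl carbon, and its reading of > 50000 nM is a limit. With no readable step to go on, no step beyond the scatter is expected in either direction, and another limit is the likeliest outcome in this assay.

For compound 4 the estimated value is 60000 nM, with an expected range from 30000 nM to 120000 nM in this assay. The expected change is an at least 1.6-fold lower number from compound 3 to compound 4 (0.22 log units; that floor lies within the scatter), and this remains only an estimate.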

Compound 4, half-maximal cytotoxic concentration: > 100000 nM
Compound 4 was reported as a limit; the forecaster's own chance of this, stated with the estimate: 85%; middle value at least 1.6-fold (0.22 log units) from the limit.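

In this assay the reading for compound 4 is a limit, just like the readings for compound 1, compound 2 and compound 3, and the steps joining compound 4 to those three cannot be read. The compounds shown leave open whether changing the group on the carbonyl carbon, or putting hydrogen in place of chloro, alters this toxicity reading at all.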